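The source may report more compounds than this note shows. Statements on the series, on what has been measured and on what is new or still open speak of the compounds shown alone.

Compound 1 `Nc1cccc(-c2cn3nc(Cc4ccc(Cl)cc4)sc3n2)c1`: 6000 nM
Compound 2 `C=C(Br)C(=O)Nc1cccc(-c2cn3c(-c4ccccc4)csc3n2)c1`: 1300 nM
Compound 3 `COc1cccc(Cc2nn3cc(-c4cccc(N)c4)nc3s2)c1`: 10000 nM

All three were tested in a functional assay on FM3A cells (Mus musculus) for inhibition, read by cell counting, with a stated time of 2 days; a lower number here means a stronger inhibitor, a higher number a weaker inhibitor. Of the three numbers, compound 2 gives the lowest, and its gaps to compound 1 and to compound 3 both lie beyond the scatter, so compound 2 is the strongest inhibitor here. Going by the values given here, the only single-point step among the measured compounds is a 1.7-fold higher number from compound 1 to compound 3 (0.22 log units; within the scatter), a swap of one aryl group for another on a saturated chain carbon, which changes the number by no more than repeated measurements would.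

Compound 4 `C=C(Br)C(=O)Nc1cccc(-c2cn3c(-c4ccc(OC)cc4)csc3n2)c1` differs from compound 2 by methoxy in place of hydrogen on an aromatic carbon. Among the compounds with values here, no measured pair tests this change on this ring: the one step seen concerns a different part of the molecule, and it was flat. With nothing pointing in either direction, the expectation for the step from compound 2 to compound 4 in this assay is no change at the digits printed from compound 2 to compound 4 (within the scatter), that is, no change beyond the scatter. Compound 4 is therefore estimated at 1300 nM, within a range of 500 nM to 3500 nM.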

Compound 4, half-maximal inhibitory concentration: 620 nM
The estimate for compound 4 lay 2.1-fold (0.32 log units) above the measured number; measured number inside the range.
By their numbers in this assay, from the lowest: compound 4; then compound 2; then compounds 1 and 3 (each within the scatter of the next).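

In this assay, the change from phenyl to 4-methoxyphenyl gives a 2.1-fold lower number from compound 2 to compound 4 (0.32 log units; beyond the scatter), a modest gain in strength that lies beyond the scatter. Going by these compounds alone, this is the first sign that the number responds to a change on this ring: a methoxy group on this aromatic carbon, para to a large group, makes compound 4 a stronger inhibitor than compound 2, whereas the only earlier step concerned a different part of the molecule and stayed within the scatter. Nothing available explains why the methoxy group has this effect.

This single pair cannot show whether the gain belongs to methoxy itself, or whether a hydroxyl group, a chlorine atom or a longer chain such as ethoxy at the same place would match or exceed it. It also leaves open whether methoxy would have the same effect on the core of compound 1.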